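The source may hold more compounds than are shown below. What is called first, only, known or untested is meant among the compounds shown, and "the series" means these compounds.

Three compounds of the series carry a measurement in an assay on HEK293 cells for positive allosteric modulation of metabotropic glutamate receptor 5 (Homo sapiens), read by FLIPR, with a stated time of 1 h; on this read-out higher numbers stand for an effect only at larger amounts of compound and lower numbers for an effect already at smaller amounts. Compound 1 `COc1ccccc1C#Cc1nc2c(s1)C(=O)NCC2` reaches only a limit of the assay, > 10000 nM. Compound 2 `O=C1c2sc(C#Cc3ccccc3)nc2CN1C1CC1` likewise sits at a limit, > 10000 nM. Among the compounds with values here, compound 3 `CC1CC(C(=O)N2CCc3nc(C#Cc4ccccc4)sc3C2)C1` gives 81 nM in this assay, the only number among the three values; the other two are the limit of > 10000 nM in this assay, at which 2 of the 3 values shown sit. Within the data shown here, no pair of measured compounds differs in one place only, so the series offers no measured step to judge a new change against.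

Compound 4 `O=C(N1CCC(F)CC1)N1CCc2nc(C#Cc3ccccc3)sc2C1` is not yet measured in this assay. Relative to compound 3 it changes as follows: 4-fluoropiperidin-1-yl in place of 3-methylcyclobutyl on a carbonyl carbon. Both groups are saturated rings without donors or acceptors, and the site of the change, the carbonyl carbon, is kept. With the numbers at hand nothing fixes a direction, so the step from compound 3 is expected to stay modest, a 1.9-fold higher number from compound 3 to compound 4 (0.27 log units; within the scatter), close to the scatter of repeated measurements. Compound 4 is therefore estimated at about 150 nM in this assay, with a range from 40 nM to 600 nM.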

Compound 4, half-maximal effective concentration: 74 nM
For compound 4 the middle estimate is 2.0-fold (0.31 log units) above the measured one, within the range that was stated.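

In this assay, within the data shown here, the change on the carbonyl carbon reads as a 1.1-fold lower number from compound 3 to compound 4 (0.04 log units; within the scatter), the only measured step. The place on the carbonyl carbon therefore accepts a six-membered non-aromatic ring with a hetero atom as well as a four-membered ring of carbon only, with no difference beyond the scatter. The fluorine and the ring nitrogen of 4-fluoropiperidin-1-yl enter together here, so this step cannot separate what either one contributes.

Still open, as far as these compounds go, is whether the same place accepts a group such as morpholin-4-yl, an unfluorinated piperidin-1-yl, a longer alkyl chain or a carboxylic acid. Compound 1 and compound 2 differ from this pair in more than one place and give no step to read, each remaining at a limit of the assay: the limit of > 10000 nM in this assay, at which 2 of the 4 values shown sit.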